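Sulfonyl aryl variation on the shared core

The source may hold more compounds than are shown below. What is called first, only, known or untested is meant among the compounds shown, and "the series" means these compounds.

Compound 2 `Cc1c(Cc2ccccc2S(=O)(=O)c2ccccc2F)c2c(n1CC(=O)O)CCNC2=O` is the starting point of the step followed here. In a functional assay on CHO.K1 cells for antagonist activity at prostaglandin D2 receptor 2 (Homo sapiens), read by GTPgammaS binding, with a stated time of 1 h (on this read-out higher numbers stand for weaker inhibition and lower numbers for stronger inhibition), compound 2 gives 3.6 nM. Compound 1 `Cc1c(Cc2cc(F)ccc2S(=O)(=O)c2ccccc2)c2c(n1CC(=O)O)CCNC2=O` in this assay gives 3.7 nM; the two numbers lie within the usual scatter of each other, so compound 2 stands at the same level as compound 1 and neither of the two can be called the stronger. Going by the values given here, no pair of measured compounds differs in one place, so no measured step is available to lean on.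

Compound 3 `COc1cccc(S(=O)(=O)c2ccccc2Cc2c3c(n(CC(=O)O)c2C)CCNC3=O)c1` differs from compound 2 in one place: 3-methoxyphenyl in place of 2-fluorophenyl on a sulfonyl sulfur. Because compound 2 gives 3.6 nM and compound 1 gives 3.7 nM, both with an aryl group on the sulfonyl sulfur, this part of the molecule is expected to accept the exchange without a large change. The step of a 1.7-fold higher number from compound 2 to compound 3 (0.22 log units; within the scatter) is expected to be small, leaning toward a slightly higher number but possibly no more than the scatter. Compound 3 is expected to give about 6 nM in this assay, with a range from 2 nM to 20 nM.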

Compound 3, half-maximal inhibitory concentration: 12 nM
The estimate for compound 3 lay 2.0-fold (0.30 log units) below the measured number; the measured number falls inside the stated range.
By their numbers in this assay, from the lowest: compounds 2 and 1 (each within the scatter of the next); then compound 3.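

In this assay, going by these compounds alone, replacing 2-fluorophenyl with 3-methoxyphenyl on a sulfonyl sulfur gives a 3.3-fold higher number from compound 2 to compound 3 (0.52 log units; beyond the scatter); this is the first one-place step, and it shows that inhibition responds to the aryl group held at this position. The response is modest, and compound 3 at 12 nM remains a nanomolar inhibitor on this read-out, so the position accepts the 3-methoxyphenyl group at a measurable but limited cost. Nothing available accounts for the size or direction of this step, so it stands as an observation only.

The step changes the substituent and its place on the aryl ring at once, so the compounds shown do not separate the loss of the fluorine from the arrival of the methoxy group, nor show how much either contributes. Also open, as far as these compounds go, is how the position would respond to an unsubstituted phenyl with the rest of the molecule as in compound 2, or to a different group on the sulfonyl sulfur, such as a pyridyl ring or an aminophenyl group.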